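The source may hold more compounds than are shown below. What is called first, only, known or untested is meant among the compounds shown, and "the series" means these compounds.

Compound 1 `Cc1c(Cc2ccccc2)c(NNC(=O)Nc2cc(Cl)nc(Cl)c2)nc2c1cnn2C`: 21400 nM
Compound 2 `Cc1nn(C)c2nc(NNC(=O)Nc3cc(Cl)nc(Cl)c3)cc(C3CC3)c12`: 80800 nM
Compound 3 `Cn1ncc2c(-c3ccc(F)cc3)cc(NNC(=O)Nc3cc(Cl)nc(OCCF)c3)nc21`: 29300 nM

In a functional assay on SW620/5-FU cells (Homo sapiens) for cytotoxicity, read by MTT assay, with a stated time of 48 h, in the presence of a further agent that is not named here (on this read-out lower numbers stand for an effect already at smaller amounts and higher numbers for an effect only at larger amounts of compound), compound 2 has the highest number of the three, and compound 3 and compound 1 both lie lower by more than the usual scatter. Compound 4 `Cc1cc(NNC(=O)Nc2cc(Cl)nc(Cl)c2)nc2c1c(C)nn2C` has not yet been measured. It carries methyl in place of cyclopropyl on an aromatic carbon, opposite the ring nitrogen: methyl in place of cyclopropyl on an aromatic carbon. Among the compounds with values here, no step between measured compounds shows this change alone, so the expectation is loose. It rests on compound 2 at 80800 nM sitting at the top of a small set that reaches down to compound 1 at 21400 nM. The estimated step is a 1.8-fold lower number from compound 2 to compound 4 (0.25 log units; within the scatter), toward a lower number and probably not beyond the scatter. For compound 4 the expected value is 45000 nM, with an estimated range of 16000 nM to 120000 nM.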

Compound 4, half-maximal effective concentration: > 100000 nM
Compound 4 gave a limit, no number (the forecaster's own chance of this, stated with the estimate: 10%); middle value at least 2.2-fold (0.34 log units) from the limit.
By their numbers in this assay, from the lowest: compounds 1 and 3 (each within the scatter of the next); then compound 2. At a limit, above all of these: compound 4.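

Methyl in place of cyclopropyl on an aromatic carbon, opposite the ring nitrogen, is the only single-place step shown at this position: an at least 1.2-fold higher number from compound 2 to compound 4 (0.09 log units; that floor lies within the scatter). In this assay, compound 4 gives only a limit, > 100000 nM, so the change brings no lower number, though the true size of the rise cannot be read: the limit of > 100000 nM in this assay, at which 1 of the 4 values shown sits.

From the compounds shown here alone, whether compound 4 truly differs from compound 2 beyond the scatter remains open. So does the effect at this position of an amine or a longer chain such as butyl.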